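Notes on the series: pyridin-4-yl in place of 4-cyanophenyl

The source may hold more compounds than are shown below. What is called first, only, known or untested is meant among the compounds shown, and "the series" means these compounds.

- Compound 1 `COC1=CC(=O)c2c(c(COc3c(F)cc(F)cc3F)c(C)n2C)C1=O` (86 nM)
- Compound 2 `COC1=CC(=O)c2c(COc3ccc([N+](=O)[O-])cc3)c(C)n(C)c2C1=O` (355 nM)
- Compound 3 `COC1=CC(=O)c2c(COc3ccc(C#N)cc3)c(C)n(C)c2C1=O` (192 nM)

In a functional assay on MIA PaCa-2 cells (Homo sapiens) for cytotoxicity, read by MTT assay, with a stated time of 72 h (a lower number here means a stronger inhibitor, a higher number a weaker inhibitor), compound 3 (192 nM) lies within the scatter of compound 2 and gives a higher number than compound 1, a gap beyond the scatter. The next case is compound 4 `COC1=CC(=O)c2c(COc3ccncc3)c(C)n(C)c2C1=O` with the change pyridin-4-yl in place of 4-cyanophenyl on an oxygen on a saturated carbon that puts pyridin-4-yl in place of 4-cyanophenyl on an oxygen on a saturated carbon. Within the data shown here, one measured step bears on this only loosely: a 1.8-fold lower number from compound 2 to compound 3 (0.27 log units; within the scatter) swaps a group on an aromatic carbon and leaves the ring itself in place. Among the measured compounds shown here, no measured step replaces that ring, so the range stays wide, and no step beyond the scatter is expected in this assay for now. The estimate amounts to a 1.3-fold higher number from compound 3 to compound 4 (0.11 log units; within the scatter) and stays within the scatter. Estimated for compound 4: 250 nM (90 nM to 700 nM).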

Compound 4, half-maximal inhibitory concentration: 3270 nM
Compound 4: the middle estimate sits 13-fold (1.12 log units) below what was measured, and the stated range ends below it.
By their numbers in this assay, from the lowest: compound 1; then compounds 3 and 2 (each within the scatter of the next); then compound 4.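

In this assay, the place on an oxygen on a saturated carbon does not tolerate every aromatic ring: pyridin-4-yl in place of 4-cyanophenyl gives a 17-fold higher number from compound 3 to compound 4 (1.23 log units; beyond the scatter). Among these compounds, the earlier swap of a group on the ring, a 1.8-fold lower number from compound 2 to compound 3 (0.27 log units; within the scatter), stayed within the scatter and gave no sign of a step this large. No available evidence accounts for its size.

Still open, from the compounds shown here alone, is whether the ring nitrogen or the absent nitrile matters more. Plain phenyl and pyridin-3-yl at this place would help to separate the two.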